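The source may report more compounds than this note shows. Statements on the series, on what has been measured and on what is new or still open speak of the compounds shown alone.

Of the compounds shown here, two sharing one core have been measured so far. In a functional assay on KB cells (Homo sapiens) for cytotoxicity, read by spectrophotometry and crystal violet staining (on this read-out higher numbers stand for weaker inhibition and lower numbers for stronger inhibition), compound 1 (`N#Cc1c(Cl)n(C2O[C@H](CF)[C@@H](O)[C@H]2O)c2cc(Cl)c(Cl)cc12`) gives 50000 nM, and compound 2 (`N#Cc1c(Cl)n(C2O[C@H](CO)[C@@H](O)[C@H]2O)c2cc(Cl)c(Cl)cc12`) gives 35000 nM. These two values lie within the scatter of each other, so compound 2 stands level with compound 1, and both numbers are high on this read-out.

The next compound is compound 3 (`N#Cc1c(Cl)n(C2O[C@H](CN=[N+]=[N-])[C@@H](O)[C@H]2O)c2cc(Cl)c(Cl)cc12`), which carries azido in place of hydroxy on a saturated chain carbon bound to a saturated ring carbon. The same difference can be read as hydroxymethyl to azidomethyl.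

Going by the values given here, only one measured step bears on this place, a 1.4-fold lower number from compound 1 to compound 2 (0.15 log units; within the scatter), which is within the scatter. It exchanged fluoro for hydroxy, so it says nothing directly about azido. Among the compounds with values here, it does show that this assay did not separate the only two groups tried at this carbon. No step beyond the scatter is therefore expected, and the expected change is a 1.2-fold lower number from compound 2 to compound 3 (0.07 log units; within the scatter). For compound 3 the estimated value is 30000 nM, with an expected range from 10000 nM to 80000 nM.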

Compound 3, half-maximal inhibitory concentration: 60000 nM
For compound 3 the middle estimate is 2.0-fold (0.30 log units) below the measured one; the range from low to high includes it.
By their numbers in this assay, from the lowest: compounds 2, 1 and 3 (each within the scatter of the next).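

With azido on a saturated chain carbon bound to a saturated ring carbon, three groups have now been tried at this carbon, and this assay separates none of them: the exchange for hydroxy gives a 1.7-fold higher number from compound 2 to compound 3 (0.23 log units; within the scatter), and the exchange for fluoro gives a 1.2-fold higher number from compound 1 to compound 3 (0.08 log units; within the scatter). The change from hydroxymethyl to azidomethyl replaces one oxygen with three nitrogen atoms and takes away a hydrogen-bond donor, yet compound 3 stands level with compound 2 and compound 1, and its number remains high on this read-out like theirs. No measurement at hand accounts for this levelness at this carbon.

As far as these compounds go, it remains open whether an amine, a carboxylic acid or a longer chain at this carbon would also stay level with these three compounds or would move the number beyond the scatter. The three compounds also share everything else in the core, so they leave open what an exchange elsewhere, such as an amide in place of the nitrile, would do to the number.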